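The source may hold more compounds than are shown below. What is called first, only, known or untested is meant among the compounds shown, and "the series" means these compounds.

Measured so far:
compound 1: `NC1=NS(=O)(=O)c2ccccc21` — 0.2
compound 2: `CCN=S1(=O)NC(=O)c2ccccc21` — 0.1

In a physicochemical assay for lipophilicity, at pH 7.4 (a higher number here means a more lipophilic compound, a lower number a more polar compound), compound 1 gives 0.2. Compound 2 gives 0.1. Compound 1 holds the higher of these two numbers, but the gap to compound 2 lies within the scatter, so the two cannot be told apart by this assay.

Compound 3, `O=S1(=O)N=C(Nc2ccccc2)c2ccccc21`, has not yet been measured in this assay. It differs from compound 1 at one place: phenyl in place of hydrogen on an amine nitrogen. A phenyl group, six carbon atoms in one aromatic ring with no hydrogen-bond donors or acceptors, enters where a hydrogen sat on the amine nitrogen.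

Among the measured compounds shown here, no pair of measured compounds shows a change of this kind, so nothing measured here sets the size of the step. The expectation is for a step upward in this assay, well beyond the scatter, with the estimate a number 1.70 log units higher from compound 1 to compound 3 (beyond the scatter). Compound 3 is expected to give about 1.9, most likely between 1.2 and 2.6. The measured value will show whether the shift is of this size.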

Compound 3, distribution coefficient: 2
The estimate for compound 3 lay 0.10 log units below the measured number; the range from low to high includes it.
By their numbers in this assay, from the lowest: compounds 2 and 1 (each within the scatter of the next); then compound 3.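

In this assay, among the compounds shown here, phenyl in place of hydrogen on an amine nitrogen gives a number 1.80 log units higher from compound 1 to compound 3 (beyond the scatter) and so forms the first step that can be read in one place. The amine nitrogen of compound 1, whose other neighbour is a carbon with a double bond to nitrogen, therefore accepts this substituent with a large upward change in the number, a point that the values of compound 1 and compound 2 alone could not show. No measurement at hand gives a reason for the size of this step.

For the compounds shown here, with only one step at this place, no trend across substituents can be stated, and it remains open how much of the change would appear with a methyl group or a longer chain on the same amine nitrogen. Also open, as far as these compounds go, is whether a carboxylic acid or an amine carried on the phenyl would keep the number near that of compound 3 or bring it back towards that of compound 1.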